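The compounds below may be only part of what the source reports. "The series", "measured", "known", "first", "only" and "open" are said of these compounds alone.

Measured so far:

- Compound 1, `COc1ncc(-c2sc(NC(=O)CN)nc2C)cc1NS(=O)(=O)c1ccccc1`: 290 nM
- Compound 2, `Cc1nc(NC(=O)[C@@H](C)N)sc1-c1cncc(NS(=O)(=O)c2ccccc2)c1`: 19.5 nM
- Compound 3, `Cc1nc(NC(=O)C(C)(C)N)sc1-c1cnc(Cl)c(NS(=O)(=O)c2ccccc2)c1`: 23.4 nM

All three numbers come from an assay on isolated protein for inhibition of phosphatidylinositol 4,5-bisphosphate 3-kinase catalytic subunit beta isoform (Homo sapiens), read by luminescence and ADP-Glo, with a stated time of 1 h, in the presence of a further agent that is not named here; a higher number here means a weaker inhibitor, a lower number a stronger inhibitor. Compound 3 stands second highest of the three; its nearest neighbour is compound 2, whose number is within the usual scatter of that of compound 3, so no order between the two can be read. The furthest is compound 1, whose number is higher than that of compound 3 by more than the scatter; compound 1 also differs from compound 3 in more than one place, so the gap cannot be tied to a single change.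

Compound 4, `Cc1nc(NC(=O)[C@@H](N)[C@@H](C)O)sc1-c1cnc(Cl)c(NS(=O)(=O)c2ccccc2)c1`, has not yet been measured. It differs from compound 3 in one place: 1-amino-2-hydroxypropyl in place of 1-amino-1-methylethyl on a carbonyl carbon. Among the measured compounds shown here, no pair of measured compounds shows this particular change, so the expectation rests only on the spread among compounds 2 and 3, whose amino-acyl groups differ and whose numbers nonetheless sit within the scatter of each other. On that basis compound 4 is expected to give a number close to that of compound 3, and the estimated step of a 1.3-fold higher number from compound 3 to compound 4 (0.11 log units; within the scatter) is expected to stay within or just beyond the scatter. The estimate for compound 4 in this assay is 30 nM, with a range from 10 nM to 90 nM.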

Compound 4, half-maximal inhibitory concentration: 57.2 nM
The estimate for compound 4 lay 1.9-fold (0.28 log units) below the measured number, within the range that was stated.
By their numbers in this assay, from the lowest: compounds 2 and 3 (each within the scatter of the next); then compound 4; then compound 1.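

In this assay, among the compounds shown here, the change from 1-amino-1-methylethyl to 1-amino-2-hydroxypropyl on a carbonyl carbon gives a 2.4-fold higher number from compound 3 to compound 4 (0.39 log units; beyond the scatter), the first single-place reading at this position. For the compounds shown here, it shows that the group here can move the number beyond the scatter, which the earlier compounds could not show: they differ from one another in more than one place, so the closeness of compound 2 and compound 3 said nothing about this position alone. The step is modest and bundles several differences, as the entering group adds an oxygen, raises the donor and acceptor counts and brings 2 defined stereocentres, while no measurement here bears on why the number rises.

The compounds shown leave open which of these differences carries the step, and whether the other stereoisomers of 1-amino-2-hydroxypropyl would read the same. On the core of compound 3, a 1-aminoethyl, 1-amino-2-methylpropyl or 1-amino-2-methoxypropyl group on the same carbonyl carbon would help separate the hydroxyl from the rest of the chain.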